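A few compounds are considered here, and "the series" means these few. Any claim that something is new, unique, unknown or untested is made for them only; others in the source may bear on it.

Measured in a functional assay on SF-295 cells (Homo sapiens) for antiproliferative activity, read by sulforhodamine B assay, with a stated time of 72 h; on this read-out lower numbers stand for stronger inhibition and higher numbers for weaker inhibition:
- compound 1 `C(=C/c1ccccc1)\C(=N\Nc1nncc2ccccc12)c1ccccc1`: 0.33 nM
- compound 2 `O=S(=O)(Nc1ncccn1)c1ccc(Nc2nncc3ccccc23)cc1`: 7.6 nM

Compound 2, at 7.6 nM, holds the higher of the two numbers in this assay. The gap down to compound 1 at 0.33 nM lies beyond the scatter. These two compounds differ in more than one place, so their gap says little about any single change.

The next compound, compound 3 `NS(=O)(=O)c1ccc(Nc2nncc3ccccc23)cc1`, has not yet been measured. Its difference from compound 2 is hydrogen in place of pyrimidin-2-yl on a sulfonamide nitrogen. Going by the values given here, no measured pair shows this change, so the data offer no direct guide to its size or direction. The expectation therefore starts from compound 2 at 7.6 nM, with a wide range, and no shift beyond the scatter is expected in this assay. The estimated change is a 1.3-fold higher number from compound 2 to compound 3 (0.12 log units; within the scatter), a slight move towards weaker inhibition at most. For compound 3 the estimated value is 10 nM, with an expected range from 2 nM to 50 nM.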

Compound 3, half-maximal inhibitory concentration: 5.3 nM
Estimate against measurement, compound 3: 1.9-fold (0.28 log units) above, and the stated range covers the measured number.
By their numbers in this assay, from the lowest: compound 1; then compounds 3 and 2 (each within the scatter of the next).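

Hydrogen in place of pyrimidin-2-yl on a sulfonamide nitrogen is the first single-place change that can be read in this series, and in this assay it amounts to a 1.4-fold lower number from compound 2 to compound 3 (0.16 log units; within the scatter). The position therefore gives up the whole pyrimidin-2-yl group, with its six-membered aromatic ring and 6 heavy atoms, without a shift that this read-out can separate from the scatter, so compound 2 and compound 3 stand level here and the ring brings no visible gain in this assay. Nothing at hand accounts for this flat step. 

Going by these compounds, this rests on a single pair, so it remains open whether a methyl or acetyl group, or a phenyl ring, on the same sulfonamide nitrogen would also leave the number in the same range. Also open, on these data alone, is what the sulfonamide itself contributes, which a carboxylic acid or a carboxamide in its place would test on the core shared by compound 2 and compound 3.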